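Carrying a Methyl Step from One Core to Another

A few compounds are considered here, and "the series" means these few. Any claim that something is new, unique, unknown or untested is made for them only; others in the source may bear on it.

Measured compounds:
compound 1, `O=C(/C=C/c1ccc(Cl)cc1)NS(=O)(=O)c1ccccc1`, 2.2 ug/mL
compound 2, `Cc1ccc(S(=O)(=O)NC(=O)/C=C/c2ccc(Cl)cc2)cc1`, 4.6 ug/mL
compound 3, `COc1ccc(/C=C/C(=O)NS(=O)(=O)c2ccccc2)cc1`, 13.2 ug/mL

All three were tested in a functional assay on B16-F10 cells (Mus musculus) for antiproliferative activity, read by ELISA and MTT assay, with a stated time of 48 h; a lower number here means a stronger inhibitor, a higher number a weaker inhibitor. Among them compound 1 gives the lowest number, and compound 3 the highest; the step of a 6.0-fold higher number from compound 1 to compound 3 (0.78 log units; beyond the scatter) separates them, and the difference between these two cores is methoxy in place of chloro on an aromatic carbon.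

Compound 2 differs from compound 1 by a single change, (methyl in place of hydrogen on an aromatic carbon), and that change produced the step of a 2.1-fold higher number from compound 1 to compound 2 (0.32 log units; beyond the scatter).

Compound 4, `COc1ccc(/C=C/C(=O)NS(=O)(=O)c2ccc(C)cc2)cc1`, has not yet been measured in this assay. It differs from compound 3 by methyl in place of hydrogen on an aromatic carbon. The place lines of the two changes agree word for word, so this is the same change that led from compound 1 to compound 2, now made on the core of compound 3.

Going by the values given here, with only one earlier example of this change, the simplest expectation is that it behaves on the core of compound 3 much as it did on the core of compound 1: the number for compound 4 is expected to rise from that of compound 3 by a step about the size of a 2.1-fold higher number from compound 3 to compound 4 (0.33 log units; beyond the scatter), resting on compound 1 to compound 2 having given a 2.1-fold higher number from compound 1 to compound 2 (0.32 log units; beyond the scatter) and on compound 3 starting from 13.2 ug/mL. A single precedent is a thin basis, so the range is kept wide. Compound 4 is therefore estimated at 28 ug/mL, between 12 ug/mL and 65 ug/mL.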

Compound 4, half-maximal inhibitory concentration: 12.2 ug/mL
Compound 4: middle estimate off by 2.3-fold (0.36 log units), on the high side; measured number inside the range.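

In this assay, adding the methyl to the core of compound 3 gave a 1.1-fold lower number from compound 3 to compound 4 (0.03 log units; within the scatter), so compound 3 and compound 4 cannot be told apart in this read-out. Taken alone, this step looks unlike the earlier one, yet the data show neither that the methyl effect depends on the core nor that it carries over unchanged, as the gap between the two steps is no larger than ordinary measurement scatter can produce: the same change on two cores in this assay, a 2.1-fold higher number (0.32 log units; beyond the scatter) from compound 1 to compound 2 and a 1.1-fold lower number (0.03 log units; within the scatter) from compound 3 to compound 4, 2.3-fold (0.35 log units) apart, within the scatter of two such steps The methoxy-for-chloro change, read on the two compounds that carry the methyl, gave a 2.7-fold higher number from compound 2 to compound 4 (0.42 log units; beyond the scatter), which is in the same direction as the step on the compounds without the methyl and agrees with it within the scatter, so this change carried over more visibly across the two cores: the same change on two cores in this assay, a 6.0-fold higher number (0.78 log units; beyond the scatter) from compound 1 to compound 3 and a 2.7-fold higher number (0.42 log units; beyond the scatter) from compound 2 to compound 4, 2.3-fold (0.35 log units) apart, within the scatter of two such steps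

With only two cores and one small group compared, the compounds shown leave open whether a step larger than the scatter would appear with an ethyl chain, a nitrile or a carboxylic acid in the place the methyl occupies. They also leave open how the methyl and methoxy-for-chloro steps would behave on a third core, for example one carrying an amine in place of the chloro or methoxy.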